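A second chloro on the urea phenyl ring

The compounds below may be only part of what the source reports. "The series", "measured", "known", "first", "only" and "open" are said of these compounds alone.

Of the compounds shown here, three sharing a common scaffold have been tested in a functional assay on NCI-H460 cells (Homo sapiens) for cytotoxicity, read by MTT assay, with a stated time of 72 h; on this read-out higher numbers stand for weaker inhibition and lower numbers for stronger inhibition. Compound 1 `CN(C)CCCNc1nc(-c2ccc(NC(=O)Nc3ccccc3Cl)cc2)nc2ccsc12` gives 430 nM in this assay. Compound 2 `CN(C)CCCNc1nc(-c2ccc(NC(=O)Nc3ccc(Cl)cc3Cl)cc2)nc2ccsc12` differs from compound 1 in one place: chloro in place of hydrogen on an aromatic carbon. In this assay, going by the values given here, compound 2 gives 1020 nM, and the step of a 2.4-fold higher number from compound 1 to compound 2 (0.38 log units; beyond the scatter) is the only measured instance of this change. Compound 3 `CN(C)CCNc1nc(-c2ccc(NC(=O)Nc3ccccc3Cl)cc2)nc2c(Cl)c(Cl)sc12` gives 440 nM in this assay; the difference between its core and the core of compound 1 is not broken down here. The numbers of compound 1 and compound 3 lie within the scatter of each other, so no order between them is claimed.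

Compound 4 `CN(C)CCNc1nc(-c2ccc(NC(=O)Nc3ccc(Cl)cc3Cl)cc2)nc2c(Cl)c(Cl)sc12` has not yet been measured. It stands to compound 3 as compound 2 stands to compound 1: chloro in place of hydrogen on an aromatic carbon. The place of the entering chloro reads the same word for word in both pairs, so this is the same change, made twice among the compounds shown.

The expectation for compound 4 rests on that one measured step, because the same change on the core of compound 1 gave a 2.4-fold higher number from compound 1 to compound 2 (0.38 log units; beyond the scatter). The step expected in this assay is a 2.4-fold higher number from compound 3 to compound 4 (0.38 log units; beyond the scatter). Compound 4 is therefore estimated to give 1050 nM in this assay, with a likely range from 500 nM to 2200 nM.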

Compound 4, half-maximal inhibitory concentration: 1520 nM
Beside the measured number, compound 4's estimate is 1.4-fold (0.16 log units) below it, and the stated range covers the measured number.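

In this assay the second chloro, which turns the 2-chlorophenyl group on the urea into a 2,4-dichlorophenyl group, gave a 3.5-fold higher number from compound 3 to compound 4 (0.54 log units; beyond the scatter), a rise in the same direction as the one seen earlier on the core of compound 1. Set side by side, the two steps point the same way and cannot be told apart in size: the same change on two cores in this assay, a 2.4-fold higher number (0.38 log units; beyond the scatter) from compound 1 to compound 2 and a 3.5-fold higher number (0.54 log units; beyond the scatter) from compound 3 to compound 4, 1.5-fold (0.16 log units) apart, within the scatter of two such steps This shows that, on these two cores, the change carried over from one to the other with a similar penalty, so the step measured on one core served as a fair guide to the step on the other; it does not show that the same would hold on any further core, since it rests on only two pairs, and it says nothing about why the number rises.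

The compounds shown leave open whether a group other than chloro in the same place on the ring, such as fluoro, methoxy or trifluoromethyl, would move the number in the same direction. They also leave open how the amine chain and the chloro groups on the core of compound 3 each bear on the number, and what a morpholine in place of the dimethylamino group would do to the step.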